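This account rests on a few compounds, and the source may have more. Where it says the series, first, only, none or still open, it means among the compounds named here.

Compound 3 `CCOC(=O)c1cnc2ccc(-c3ccc(C(C)C)cc3)cc2c1` carries an ethyl ester on the shared core and an isopropyl group on the attached benzene ring. In a functional assay on RD cells (Homo sapiens) for inhibition, read by luminescence and ATP content, with a stated time of 72 h (on this read-out lower numbers stand for higher toxicity in this test and higher numbers for lower toxicity in this test), compound 3 gives > 7400 nM, which is a limit of the assay and not a number. Compound 1 `CCCc1ccc(-c2ccc3ncc(C(=O)OCC)cc3c2)cc1` bears a propyl group in the same place. In this assay compound 1 gives > 7400 nM, again a limit. Compound 2 `CCOC(=O)c1cnc2ccc(-c3cccc(N)c3)cc2c1` carries an amino-substituted benzene ring instead. In this assay compound 2 gives > 7400 nM, also a limit. Where compound 3 stands among these numbers cannot be told, since every value rests at the limit of > 7400 nM in this assay, at which 3 of the 3 values shown sit. The step that the two limits leave unreadable from compound 1 to compound 3 is therefore of unreadable size. Compound 4 `CCCCc1ccc(-c2ccc3ncc(C(=O)OCC)cc3c2)cc1` differs from compound 3 by butyl in place of isopropyl on an aromatic carbon. For the measured compounds named here, the only related step, from propyl to isopropyl, could not be read, so no step beyond the scatter is expected in this assay. Compound 4 is estimated at 10000 nM, with a range from 5000 nM to 30000 nM, most likely reported again only as a limit. The expected step is a step that the limit leaves unreadable from compound 3 to compound 4.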

Compound 4, half-maximal cytotoxic concentration: > 7400 nM
Compound 4 ended at the assay's limit; the forecaster's own chance of this, stated with the estimate: 85%; the middle value is on the limit's open side.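

No step can be read from compound 3 to compound 4, or from compound 1 to compound 4, because each value is a limit of the assay and not a number: the limit of > 7400 nM in this assay, at which 4 of the 4 values shown sit.

The compounds shown leave open whether the butyl, propyl, isopropyl or amino-substituted compounds differ at all in toxicity in this assay.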